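The source may hold more compounds than are shown below. What is called first, only, known or untested is meant among the compounds shown, and "the series" means these compounds.

In a functional assay on HCT-116 cells (Homo sapiens) for antiproliferative activity, read by MTT assay, with a stated time of 48 h (on this read-out higher numbers stand for weaker inhibition and lower numbers for stronger inhibition), the three measured compounds are:
Compound 1 `Cc1cnc(Nc2ccc(S(C)(=O)=O)cc2)nc1Nc1nc2ccc(Cl)cc2s1` gives 2500 nM.
Compound 2 `CS(=O)(=O)c1ccc(Nc2nccc(Nc3nc4ccc(Cl)cc4s3)n2)cc1` gives 1350 nM.
Compound 3 `NS(=O)(=O)c1ccc(Nc2nccc(Nc3nc4ccc(F)cc4s3)n2)cc1` gives 700 nM.

Compound 2 and compound 1 differ in one place, (methyl in place of hydrogen on an aromatic carbon), and this change made a step of a 1.9-fold higher number from compound 2 to compound 1 (0.27 log units; within the scatter). Compound 3 is compared with compound 4 `Cc1cnc(Nc2ccc(S(N)(=O)=O)cc2)nc1Nc1nc2ccc(F)cc2s1`, which is not yet measured; the two differ by the same change, (methyl in place of hydrogen on an aromatic carbon), at the same place. How the core of compound 3 differs from that of compound 2 is not broken down here; the two numbers simply show compound 3 with the lower number, and the gap to compound 2 is within the scatter.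

For compound 4 a step of a 1.9-fold higher number from compound 3 to compound 4 (0.27 log units; within the scatter) is expected in this assay, resting on the earlier step of a 1.9-fold higher number from compound 2 to compound 1 (0.27 log units; within the scatter) made by the same change in compound 1. Compound 4 is therefore estimated at 1300 nM, between 550 nM and 3200 nM.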

Compound 4, half-maximal inhibitory concentration: 2010 nM
For compound 4 the middle estimate is 1.5-fold (0.19 log units) below the measured one; low and high end bracket the measured number.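

In this assay, methyl in place of hydrogen on an aromatic carbon gives a 2.9-fold higher number from compound 3 to compound 4 (0.46 log units; beyond the scatter) and so points the same way as the earlier step, and the two steps do not differ beyond the scatter: the same change on two cores in this assay, a 1.9-fold higher number (0.27 log units; within the scatter) from compound 2 to compound 1 and a 2.9-fold higher number (0.46 log units; beyond the scatter) from compound 3 to compound 4, 1.6-fold (0.19 log units) apart, within the scatter of two such steps. Across these two cores, then, the change carries over in direction and, within the scatter, in size. Within the data shown here, this rests on only two pairs, and only the new step lies beyond the scatter, so it shows neither that the change would act alike on other cores nor why it acts as it does.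

The compounds shown carry only hydrogen or methyl at this place. Going by these compounds, what an ethyl group, a longer chain or an amine would do there stays open.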